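One cap change, carried over to a second core

The source may report more compounds than this note shows. Statements on the series, on what has been measured and on what is new or still open speak of the compounds shown alone.

Compound 1, `CC(C)[C@H](NC(=O)OCc1ccccc1)C(=O)N1CCCC[C@H]1C(=O)N[C@@H](CCCNC(=N)N)C(=O)CF`, gives 730 nM in a functional assay on OCI-Ly3 cells (Homo sapiens) for inhibition, read by CellTiter-Glo, with stated times of 48 h and 96 h; on this read-out lower numbers stand for stronger inhibition of growth and higher numbers for weaker inhibition of growth.
Compound 2, `CC(C)[C@H](NC(=O)OCc1ccccc1)C(=O)N1C[C@H](O)C[C@H]1C(=O)N[C@@H](CCCNC(=N)N)C(=O)CF`, gives 290 nM in this assay.
Compound 3, `CC(C)[C@H](NC(=O)c1ccc(Br)cc1)C(=O)N1C[C@H](O)C[C@H]1C(=O)N[C@@H](CCCNC(=N)N)C(=O)CF`, gives 70 nM in this assay.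

Compound 1 and compound 2 carry the same cap on the same carbonyl carbon but sit on different cores; the difference between the two cores is not broken down here. Compound 1 has the highest number of the three. Compound 2 and compound 3 share a core and differ in one place: 4-bromophenyl in place of benzyloxy on a carbonyl carbon. This change gave a 4.1-fold lower number from compound 2 to compound 3 (0.62 log units; beyond the scatter).

Compound 4, `CC(C)[C@H](NC(=O)c1ccc(Br)cc1)C(=O)N1CCCC[C@H]1C(=O)N[C@@H](CCCNC(=N)N)C(=O)CF`, is not yet measured. It applies the same change to the core of compound 1: 4-bromophenyl in place of benzyloxy on a carbonyl carbon. The place is the same in both pairs, so this is the same change, only on a different core.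

Because the change gave a 4.1-fold lower number from compound 2 to compound 3 (0.62 log units; beyond the scatter), a step of similar size is expected here, a 4.1-fold lower number from compound 1 to compound 4 (0.61 log units; beyond the scatter), starting from the number of compound 1, 730 nM. Whether a second core carries the step equally well is not known, so the range is kept wide. Compound 4 is therefore expected to give 180 nM, between 70 nM and 450 nM.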

Compound 4, concentration for 50% growth inhibition: 460 nM
The estimate for compound 4 lay 2.6-fold (0.41 log units) below the measured number, outside the stated range (above it).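

On the second core, 4-bromophenyl in place of benzyloxy on the carbonyl carbon gave a 1.6-fold lower number from compound 1 to compound 4 (0.20 log units; within the scatter) in this assay, a step that on its own cannot be told apart from the ordinary scatter of repeated measurements. Set beside the step on the first core, the new step does not differ from it by more than such measurements allow: the same change on two cores in this assay, a 4.1-fold lower number (0.62 log units; beyond the scatter) from compound 2 to compound 3 and a 1.6-fold lower number (0.20 log units; within the scatter) from compound 1 to compound 4, 2.6-fold (0.42 log units) apart, within the scatter of two such steps. This means the change is not shown to carry over to the second core with a clear effect, but it is also not shown to work differently there, since a single pair on each core cannot separate a true effect of the core from scatter.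

The compounds shown leave open how other caps on the same carbonyl carbon, such as a plain phenyl, a 4-chlorophenyl or a chain ending in a carboxylic acid, would behave on these two cores. They also leave open whether the step would hold on any further core.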